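Working notes on the step from compound 3 to compound 4

The source may hold more compounds than are shown below. What is called first, only, known or untested is meant among the compounds shown, and "the series" means these compounds.

In a functional assay on MDA-MB-231 cells (Homo sapiens) for inhibition, read by MTT assay, with a stated time of 24 h (on this read-out higher numbers stand for weaker inhibition of growth and lower numbers for stronger inhibition of growth), compound 1 (`N[C@@H](CC(=O)OC[C@H]1O[C@@H](n2cc(F)c(=O)[nH]c2=O)C[C@@H]1O)C(=O)O`) gives 29300000 nM while compound 2 (`N[C@@H](CC(=O)OC[C@H]1O[C@@H](n2cc(F)c(=O)[nH]c2=O)C[C@@H]1OC(=O)C[C@H](N)C(=O)O)C(=O)O`) gives 33100000 nM and compound 3 (`CC(C)[C@H](N)C(=O)OC[C@H]1O[C@@H](n2cc(F)c(=O)[nH]c2=O)C[C@@H]1O`) gives 38100000 nM on the same read-out. Compound 3 thus stands level with the other two: its value lies within the scatter of both, and no order can be read among the three.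

Compound 4 (`CC(C)[C@H](N)C(=O)OC[C@H]1O[C@@H](n2cc(F)c(=O)[nH]c2=O)C[C@@H]1OC(=O)[C@@H](N)C(C)C`) differs from compound 3 in one place: (1-amino-2-methylpropyl)carbonyl in place of hydrogen on an oxygen on a saturated carbon (in words, (1-amino-2-methylpropyl)carbonyl in place of hydrogen on an oxygen on a saturated carbon). The closest measured precedent is a 1.1-fold higher number from compound 1 to compound 2 (0.05 log units; within the scatter) for (2-amino-2-carboxyethyl)carbonyl in place of hydrogen on an oxygen on a saturated carbon, a step within the scatter. The other measured step is a 1.3-fold higher number from compound 1 to compound 3 (0.11 log units; within the scatter) for 1-amino-2-methylpropyl in place of 2-amino-2-carboxyethyl on a carbonyl carbon, again within the scatter. The group entering here has not yet been measured at this oxygen, and only these two steps inform the expectation, so the range stays wide. The step expected in this assay is a 1.0-fold higher number from compound 3 to compound 4 (0.02 log units; within the scatter) and nothing beyond the scatter is anticipated. The estimate for compound 4 is 40000000 nM with 20000000 nM to 80000000 nM as the expected range.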

Compound 4, concentration for 50% growth inhibition: 31700000 nM
Estimate against measurement, compound 4: 1.3-fold (0.10 log units) above; low and high end bracket the measured number.
By their numbers in this assay, from the lowest: compounds 1, 4, 2 and 3 (each within the scatter of the next).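

In this assay, (1-amino-2-methylpropyl)carbonyl in place of hydrogen on an oxygen on a saturated carbon gives a 1.2-fold lower number from compound 3 to compound 4 (0.08 log units; within the scatter). Read with a 1.1-fold higher number from compound 1 to compound 2 (0.05 log units; within the scatter), this gives a second acyl group at this oxygen, on a second parent carrying a different ester, and again no step beyond the scatter; compounds 1 to 4 hold no step against this, though two steps are a narrow base. Nothing at hand accounts for this insensitivity, or says whether the measured growth inhibition comes from the intact esters or from something released from them.

Still open, going by these compounds, is whether an acyl group without the amine at this oxygen, such as a plain acetyl or a longer chain such as hexanoyl, would give a step beyond the scatter. Also open, on these data alone, is where these four stand against the shared core with a hydroxy on both oxygens, a comparison that would show whether either ester matters at all on this read-out.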